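The compounds below may be only part of what the source reports. "The series", "measured", "known", "first", "only" and "open" are said of these compounds alone.

Among the measured compounds shown here, compound 2 `COc1cc(Cl)cc(-c2nn(-c3cccc(NC(=O)Nc4ccc(Cl)c(Cl)c4)c3)cc2-c2ccncc2)c1` has the higher of the two numbers measured so far in a functional assay on SNB-19 cells (Homo sapiens) for inhibition, read by sulforhodamine B assay, with a stated time of 48 h, tested at 100 uM; on this read-out higher numbers stand for a weaker effect at the one concentration tested and lower numbers for a stronger effect: compound 2 gives 10%, while compound 1 `O=C(Nc1cccc(-n2cc(-c3ccncc3)c(-c3cc(O)cc(Cl)c3)n2)c1)Nc1ccc(Cl)c(Cl)c1` gives -26%. For the measured compounds named here, the one measured step between them, a number 36 percentage points higher from compound 1 to compound 2 (beyond the scatter), comes from a methyl in place of hydrogen on an oxygen on an aromatic ring; that part of the shared core stays untouched in what follows. Compound 3 `COc1cc(Cl)cc(-c2nn(-c3cccc(NC(=O)c4cccc(C(F)(F)F)c4)c3)cc2-c2ccncc2)c1` differs from compound 2 at another place: 3-(trifluoromethyl)phenyl in place of (3,4-dichlorophenyl)amino on a carbonyl carbon. Going by the values given here, no measured step touches this carbonyl carbon, so the only step in hand, the one running from compound 1 to compound 2, says nothing direct about it, and the value of compound 1 on its own does not either. With nothing to build on but the fact that the rest of the molecule is kept, the expectation is a step of no change at the digits printed from compound 2 to compound 3 (within the scatter) in this assay, that is, no change beyond the scatter, with a wide allowance either way. Compound 3 is therefore expected to give about 10% in this assay, with a range from -30% to 50%.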

Compound 3, a percentage reported as activity, at one concentration (the size of the read-out at that concentration, not a potency): 72%
Compound 3: the middle estimate sits 62 percentage points below what was measured, and the stated range ends below it.
By their numbers in this assay, from the lowest: compound 1; then compound 2; then compound 3.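

Placing 3-(trifluoromethyl)phenyl instead of (3,4-dichlorophenyl)amino on the carbonyl carbon gives a number 62 percentage points higher from compound 2 to compound 3 (beyond the scatter) in this assay, so compound 3 has the weaker effect at the one concentration tested and this position clearly matters for the read-out. Among the compounds shown here, until now, the only measured change was on the aromatic oxygen, a number 36 percentage points higher from compound 1 to compound 2 (beyond the scatter) in this assay, so this is a second place on the molecule where one change moves the number beyond the scatter. The swap alters several things at once, removing the amide-type nitrogen's neighbouring nitrogen with its hydrogen-bond donor and replacing two chlorines with a trifluoromethyl group, and no measurement is available to explain why the number rises.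

The compounds shown leave open whether the lost nitrogen or the different ring substituents account for the step, a question that (3-(trifluoromethyl)phenyl)amino on the same carbonyl carbon could help to separate. Also open, as far as these compounds go, is how other groups at this position, such as a simple amine or a longer alkyl chain, would read, and whether the step holds with hydrogen in place of the methyl on the oxygen.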